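Replacing the Nitrogen Substituent of a Weak Inhibitor

The compounds below may be only part of what the source reports. "The series", "measured", "known", "first", "only" and "open" are said of these compounds alone.

In a functional assay on MV4-11 cells (Homo sapiens) for antiproliferative activity, read by luminescence and CellTiter-Glo, with a stated time of 72 h (on this read-out higher numbers stand for weaker inhibition and lower numbers for stronger inhibition), compound 1 `Cc1noc(C)c1-c1ccc2c(Nc3ccc(F)cc3)nn(C3CCCCO3)c2c1` gives 9900 nM. Compound 2 `COc1cc(F)ccc1Nc1nn(C2CCCCO2)c2cc(-c3c(C)noc3C)ccc12` gives 8500 nM, so the two stand level: a 1.2-fold lower number from compound 1 to compound 2 (0.07 log units; within the scatter) lies within the scatter of repeated measurements. Both numbers are high on a scale where lower means stronger inhibition.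

Compound 3 `COc1ccc(Cn2nc(Nc3ccc(F)cc3)c3ccc(-c4c(C)noc4C)cc32)cc1` has not yet been measured. It keeps the core of compound 1 and differs in one place, with 4-methoxybenzyl in place of oxan-2-yl on an aromatic nitrogen.

Among the measured compounds shown here, only one measured step is available, and it does not touch this nitrogen. It is a methoxy in place of hydrogen on an aromatic carbon, and its size, a 1.2-fold lower number from compound 1 to compound 2 (0.07 log units; within the scatter), says little about the new change. The expectation must therefore start from compound 1 at 9900 nM, with a wide margin on both sides. The expected change is small and leans towards a lower number in this assay, as a 1.7-fold lower number from compound 1 to compound 3 (0.22 log units; within the scatter). For compound 3 the estimated value is 6000 nM, with an expected range of 1500 nM to 20000 nM.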

Compound 3, half-maximal inhibitory concentration: 9100 nM
Compound 3: the middle estimate sits 1.5-fold (0.18 log units) below what was measured; the measured number falls inside the stated range.
By their numbers in this assay, from the lowest: compounds 2, 3 and 1 (each within the scatter of the next).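

At this aromatic nitrogen of the shared core, a six-membered non-aromatic ring can give way to 4-methoxybenzyl, with its six-membered aromatic ring of carbon only, and in this assay the two compounds still stand level, with a 1.1-fold lower number from compound 1 to compound 3 (0.04 log units; within the scatter). Among the compounds shown here, this is the first look at this nitrogen, since the earlier step touched only an aromatic carbon, and it shows that these two quite different groups cannot be told apart here, with the number staying high on a scale where lower means stronger inhibition. Nothing available explains why the two groups read alike.

With only oxan-2-yl and 4-methoxybenzyl on this nitrogen, the compounds shown leave open whether any group here can shift the number beyond the scatter, for instance a plain hydrogen, a short chain ending in an amine, or a chain ending in a carboxylic acid. They also leave open how 4-methoxybenzyl on this nitrogen would read together with the methoxy group that sets compound 2 apart from compound 1.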